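Replacing 3,4-difluorophenyl with 4-hydroxyphenyl in compound 1

The source may report more compounds than this note shows. Statements on the series, on what has been measured and on what is new or still open speak of the compounds shown alone.

For the measured compounds named here, in a functional assay on DU-145 cells (Homo sapiens) for cytotoxicity (on this read-out lower numbers stand for stronger inhibition of growth and higher numbers for weaker inhibition of growth), compound 1 (`CSc1ccc(C2=C(c3ccc(F)c(F)c3)C(=O)N3CCCC3C2)cc1`) gives 500 nM and stands lowest of the two numbers measured so far. Going by the values given here, compound 2 (`COc1ccc(C2=C(c3ccc(SC)cc3)CC3CCCN3C2=O)cc1OC`) gives 1500 nM and that gap lies beyond the usual scatter, though no measured pair differs in only one place. Compound 3 (`CSc1ccc(C2=C(c3ccc(O)cc3)C(=O)N3CCCC3C2)cc1`) keeps the core of compound 1 but carries 4-hydroxyphenyl in place of 3,4-difluorophenyl on a double-bonded ring carbon. Neither measured compound carries 4-hydroxyphenyl, so the data offer no direct guide. Among the compounds with values here, with compound 1 at 500 nM as the lower of only two numbers, a modest rise in this assay seems likelier than a fall, and it may stay close to the scatter. The estimated step (a 1.6-fold higher number from compound 1 to compound 3 (0.20 log units; within the scatter)) is therefore expected to be small. For compound 3 the estimated value is 800 nM with an expected range from 200 nM to 3000 nM as its likely span.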

Compound 3, concentration for 50% growth inhibition: > 100000 nM
Compound 3: a limit, no number; the forecaster's own chance of this, stated with the estimate: 10%; middle value at least 120-fold (2.09 log units) from the limit.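

In this assay compound 3 gives > 100000 nM, which is a limit of the assay and not a number. For the compounds shown here, the single change gives an at least 200-fold higher number from compound 1 to compound 3 (2.30 log units; beyond the scatter), so with the core of compound 1 held fixed, the group on this double-bonded ring carbon matters greatly: 4-hydroxyphenyl in place of 3,4-difluorophenyl is enough to take growth inhibition out of the range this read-out reports. Compound 1 and compound 2 differ in more than one place and could not show this, and the full size of the step stays unknown: the limit of > 100000 nM in this assay, at which 1 of the 3 values shown sits.

The swap removes both fluorines and adds a hydroxyl in one move, so the compounds shown cannot say which of these matters. Open too, going by these compounds, is where a plain phenyl or a 4-methoxyphenyl at this carbon would fall.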